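The source may hold more compounds than are shown below. What is called first, only, known or untested is meant among the compounds shown, and "the series" means these compounds.

Compound 1 `Cc1ccc(-n2cc(-c3ccc(NS(=O)(=O)c4c[nH]c(=O)[nH]c4=O)cc3)nn2)cc1`: "not toxic" (no number reported) in an ADME assay on GES1 cells (Homo sapiens) for cytotoxicity, read by MTT assay, with a stated time of 24 h; a lower number here means that less compound is tolerated, a higher number that more compound is tolerated.
Compound 2 `O=c1[nH]cc(S(=O)(=O)Nc2ccc(-c3cn(-c4cccc(F)c4)nn3)cc2)c(=O)[nH]1`: "not toxic" (no number reported) in this assay.
Compound 3 `O=c1[nH]cc(S(=O)(=O)Nc2ccc(-c3cn(-c4ccccc4Cl)nn3)cc2)c(=O)[nH]1`: 16400 nM in this assay.

Within the data shown here, compound 3 carries the only number in this assay; compound 1 and compound 2 are recorded without a figure. The next entry is compound 4 `O=c1[nH]cc(S(=O)(=O)Nc2ccc(-c3cn(-c4ccc(Cl)cc4)nn3)cc2)c(=O)[nH]1`, which differs from compound 3 by 4-chlorophenyl in place of 2-chlorophenyl on an aromatic nitrogen. Among the measured compounds shown here, no measured pair in this set shows what such a change does, so the size of the step is open. The expectation is a step of a 1.5-fold higher number from compound 3 to compound 4 (0.18 log units; within the scatter) from compound 3, not clearly beyond the scatter, with the chance that only a "not toxic" entry results. Compound 4 is estimated at 25000 nM, within 8000 nM to 80000 nM.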

Compound 4, half-maximal cytotoxic concentration: 23300 nM
Compound 4: the middle estimate sits 1.1-fold (0.03 log units) above what was measured; the range from low to high includes it.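

Among these compounds, exchanging 2-chlorophenyl for 4-chlorophenyl on the aromatic nitrogen gives the first readable step in this assay, a 1.4-fold higher number from compound 3 to compound 4 (0.15 log units; within the scatter). At this position, the two chlorophenyl isomers are therefore not told apart by this read-out. No measurement bearing on the reason for this result is available.

From the compounds shown here alone, whether a different group at this position, such as a pyridine ring, an aminophenyl or a carboxylic acid on the phenyl, would stay as close remains open. Steps to compound 1 and compound 2 cannot be read, as their "not toxic" entries carry no figure.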